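The source may hold more compounds than are shown below. What is called first, only, known or untested is meant among the compounds shown, and "the series" means these compounds.

Within the data shown here, compound 2 `CC(C)C[C@H](N)c1cc(C(F)(F)F)ccc1N1CCN(C(=O)CCc2ccc(S(C)(=O)=O)cc2)CC1` carries a 2-(4-(methylsulfonyl)phenyl)ethyl chain, and in an assay on HEK293 cells for displacement of a labelled ligand from Melanocortin receptor 4 (Homo sapiens) (a higher number here means a weaker inhibitor, a lower number a stronger inhibitor), compound 2 gives 4900 nM, the only plain number among the values shown. Its partner compound 1 `CC(C)C[C@H](N)c1cc(C(F)(F)F)ccc1N1CCN(C(=O)CCc2ccc(O)cc2)CC1` differs only in the group on the aromatic ring. In this assay compound 1 gives only a limit, > 10000 nM. Among the measured compounds shown here, the single measured step, an at least 2.0-fold lower number from compound 1 to compound 2 (0.30 log units; that floor lies within the scatter), therefore rests on a floor the limit of > 10000 nM in this assay, at which 1 of the 2 values shown sits, and says little more than that the two compounds are both weak. Compound 3 `CC(C)C[C@H](N)c1cc(C(F)(F)F)ccc1N1CCN(C(=O)CCc2cccs2)CC1` is not yet measured; it changes compound 2 by thiophen-2-yl in place of 4-(methylsulfonyl)phenyl on a saturated chain carbon, two bonds along the chain from a carbonyl carbon. For the measured compounds named here, no measured step swaps the whole aryl group, so the expectation for this assay is wide and leans on compound 2 alone with its value 4900 nM. Compound 3 is expected to stay in the same weak range, with an estimated 1.2-fold higher number from compound 2 to compound 3 (0.09 log units; within the scatter) and a value of about 6000 nM, between 2000 nM and 20000 nM.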

Compound 3, inhibition constant: 4600 nM
Compound 3: the middle estimate sits 1.3-fold (0.12 log units) above what was measured; the measured number falls inside the stated range.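

The step from 4-(methylsulfonyl)phenyl to thiophen-2-yl, with no sulfonyl group left on the ring, reads a 1.1-fold lower number from compound 2 to compound 3 (0.03 log units; within the scatter) in this assay, so at this position the two groups cannot be told apart. Measured from the 4-hydroxyphenyl group, thiophen-2-yl reads an at least 2.1-fold lower number from compound 1 to compound 3 (0.33 log units; beyond the scatter), and unlike the earlier floor, this one clears the scatter, though only modestly. It remains a floor and not a measured size, since one end of it is a limit of the assay: the limit of > 10000 nM in this assay, at which 1 of the 3 values shown sits.

As far as these compounds go, compound 2 and compound 3 are both weak, so it stays open whether any group on this chain can give a much lower number. A plain phenyl, a pyridine ring or a longer chain ending in thiophen-2-yl could begin to answer that.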